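Benzyloxy for chloro on the pendant aryl ring

The source may report more compounds than this note shows. Statements on the series, on what has been measured and on what is new or still open speak of the compounds shown alone.

Compound 1 `CC(=O)n1cc(/C=C(/C(=O)O)c2ccc(Cl)cc2)c2cc(OCc3ccccc3)ccc21` carries a 4-chlorophenyl group on the double-bonded chain carbon bound to the carbonyl carbon. In a functional assay on M14 cells (Homo sapiens) for cytotoxicity, read by MTT assay, with a stated time of 72 h (a higher number here means a weaker inhibitor, a lower number a stronger inhibitor), compound 1 gives only a limit of > 100000 nM rather than a number. The note the limit of > 100000 nM in this assay, at which 2 of the 3 values shown sit, marks where two of the three recorded values sit.

Among the compounds with values here, compound 2 `COc1ccc(/C(=C\c2cn(C(C)=O)c3ccc(OCc4ccccc4)cc23)C(=O)O)cc1OC` is the one member with a numerical value; in this assay compound 2 gives 65500 nM. Compound 3 `COc1cccc(/C(=C\c2cn(C(C)=O)c3ccc(OCc4ccccc4)cc23)C(=O)O)c1` returns only a limit of > 100000 nM in this assay and not a number. The step of an at least 1.5-fold lower number from compound 1 to compound 2 (0.18 log units; that floor lies within the scatter) and the step of an at least 1.5-fold higher number from compound 2 to compound 3 (0.18 log units; that floor lies within the scatter) are both floors that lie within the scatter, and the step that the two limits leave unreadable from compound 1 to compound 3 cannot be read from two limits.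

Compound 4 `CC(=O)n1cc(/C=C(/C(=O)O)c2ccc(OCc3ccccc3)cc2)c2cc(OCc3ccccc3)ccc21` differs from compound 1 as follows: benzyloxy in place of chloro on an aromatic carbon. Within the data shown here, no measured step changes this position on its own; the nearest comparison is the aryl exchange in an at least 1.5-fold lower number from compound 1 to compound 2 (0.18 log units; that floor lies within the scatter), which moved the value off the limit only marginally. Nothing in the series shows a reading off the limit that lies beyond the scatter. Compound 4 is therefore expected to stay near the limit, with the step of an at least 1.1-fold lower number from compound 1 to compound 4 (0.04 log units; that floor lies within the scatter) estimated as small at most. The estimate for compound 4 in this assay is 90000 nM, ranging from 30000 nM to 300000 nM, with a real chance that only a limit is reported.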

Compound 4, half-maximal inhibitory concentration: 58200 nM
Estimate against measurement, compound 4: 1.5-fold (0.19 log units) above; measured number inside the range.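

In this assay compound 4 gives 58200 nM, so the aromatic carbon para to a large group accepts benzyloxy, with its 8 heavy atoms and six-membered aromatic ring, and the assay still returns a number rather than a limit. Unlike the exchanges in compound 2 and compound 3, this change replaces only the chloro group and leaves the rest of the pendant ring unsubstituted, giving an at least 1.7-fold lower number from compound 1 to compound 4 (0.23 log units; that floor lies within the scatter); as a floor within the scatter, this step establishes no gain in potency. Numbers now stand for compound 2 and compound 4, while compound 1 and compound 3 remain limits: the limit of > 100000 nM in this assay, at which 2 of the 4 values shown sit.

The compounds shown leave open whether an amine or a longer chain than benzyloxy on that same aromatic carbon would give a step beyond the scatter, and whether any such step would follow the size of the group. Also open, on these data alone, is the true distance between compound 1 and compound 4, which stays unknown while compound 1 is held only by its limit.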